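From hydroxy to 4-methoxyphenyl on the shared core

The source may report more compounds than this note shows. Statements on the series, on what has been measured and on what is new or still open speak of the compounds shown alone.

In a functional assay on MIA PaCa-2 cells (Homo sapiens) for cytotoxicity, read by MTT assay (a lower number here means a stronger inhibitor, a higher number a weaker inhibitor), compound 1 (`COc1cc2ncnc(Nc3cc(O)[nH]n3)c2cc1OC`) gives < 100000 nM as a limit of the assay, not a number. Compound 2 (`COc1cc2ncnc(Nc3cc(-c4ccccc4)[nH]n3)c2cc1OC`) gives < 100000 nM and this too is a limit. Compound 3 (`COc1ccc(-c2cc(Nc3ncnc4cc(OC)c(OC)cc34)n[nH]2)cc1`) keeps the core of compound 1 and carries 4-methoxyphenyl in place of hydroxy on an aromatic carbon. The closest measured change is phenyl in place of hydroxy (a step that the two limits leave unreadable from compound 1 to compound 2), and its size cannot be read, as both compounds sit at one limit (the limit of < 100000 nM in this assay, at which 2 of the 2 values shown sit). Among the compounds with values here, no measured step therefore sets a size or direction for the change to compound 3, and any expectation must stay broad. An estimated step (a step that the limit leaves unreadable from compound 1 to compound 3) is offered with its direction uncertain. For compound 3 the expected value is 30000 nM with an estimated range from 5000 nM to 100000 nM in this assay as the likely span.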

Compound 3, half-maximal inhibitory concentration: < 100000 nM
Compound 3: only a limit was reported; the forecaster's own chance of this, stated with the estimate: 50%; the middle value lies beyond the limit too.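

No new step can be read: compound 3 is reported only as a limit, and so are compound 1 and compound 2, which leaves its steps from both unreadable: the limit of < 100000 nM in this assay, at which 3 of the 3 values shown sit.

The compounds shown leave open how strong each one is in this assay, and whether hydroxy, phenyl or 4-methoxyphenyl on the shared core makes any difference there.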